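A few compounds are considered here, and "the series" means these few. Any claim that something is new, unique, unknown or untested is made for them only; others in the source may bear on it.

Working notes on the series. Three compounds have so far been run in a functional assay on THP-1 cells (Homo sapiens) for inhibition, read by ELISA, with stated times of 2 h and 48 h; a lower number here means a stronger inhibitor, a higher number a weaker inhibitor. Compound 1 `CCOC1=C(/C(C)=N/OCC(=O)Nc2ccc(Cl)c(C(F)(F)F)c2)N(C)S(=O)(=O)c2ccccc21` gives only a limit of the assay, > 20000 nM. Compound 2 `C/C(=N\OCC(=O)Nc1ccccc1)C1=C(O)c2ccccc2S(=O)(=O)N1C` also gives only a limit, > 20000 nM. Compound 3 `COc1ccc(NC(=O)CO/N=C(\C)C2=C(O)c3ccccc3S(=O)(=O)N2C)cc1` likewise stops at a limit, > 20000 nM. Compound 2 therefore stands at the limit and not at a number. The whole picture is summed up by the limit of > 20000 nM in this assay, at which 3 of the 3 values shown sit. For the measured compounds named here, the one measured step on the shared core, a step that the two limits leave unreadable from compound 2 to compound 3, is of a size that cannot be read, since both ends are limits.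

Compound 4 `C/C(=N\OCC(=O)Nc1c(F)cccc1F)C1=C(O)c2ccccc2S(=O)(=O)N1C` is the next to be measured in this assay. It differs from compound 2 by 2,6-difluorophenyl in place of phenyl on an amide-type nitrogen. The step from compound 2 to compound 3 is the only measured one touching the group on the amide-type nitrogen, and it bears on this change, but its size is unreadable. No step beyond the scatter is known in this assay, and every value sits at the limit. The expected step is a step that the limit leaves unreadable from compound 2 to compound 4, that is, none that could be resolved. Compound 4 is expected to remain at or near the limit, estimated at 30000 nM within a range of 10000 nM to 100000 nM.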

Compound 4, half-maximal inhibitory concentration: > 20000 nM
Compound 4: no number, only a limit; the forecaster's own chance of this, stated with the estimate: 80%; the middle value is on the limit's open side.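

Compound 4 gives only a limit, like compound 2 and compound 3, so no step from either of them to compound 4 can be read: the limit of > 20000 nM in this assay, at which 4 of the 4 values shown sit.

The compounds shown leave open whether any group on the amide-type nitrogen changes inhibition on the shared core at all.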